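Series notes: aryl-piperazine variation on a shared oxazole core

The source may report more compounds than this note shows. Statements on the series, on what has been measured and on what is new or still open speak of the compounds shown alone.

Measured so far:
- compound 1 `CCCc1nc(-c2ccccc2)c(CNCCCN2CCN(c3ccc(F)cc3)CC2)o1`: 62.5%
- compound 2 `CCCc1nc(-c2ccccc2)c(CNCCN2CCN(C(c3ccccc3)c3ccccc3)CC2)o1`: 71.9%

Both compounds were examined in an assay on HEK293 cells for inhibition of Voltage-dependent T-type calcium channel subunit alpha-1G (Homo sapiens), read by fluorescence, tested at 10 uM; on this read-out lower numbers stand for less inhibition and higher numbers for more inhibition at the one concentration tested (going by the name of the read-out). Compound 1 gives 62.5% and compound 2 gives 71.9%. On the two numbers as they stand, compound 1 holds the lower one, but the gap to compound 2 lies within the usual scatter of such measurements, so no order between the two can be read from these data.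

The next compound, compound 3 `CCCc1nc(-c2ccccc2)c(CNCCCN2CCN(c3ccc(C(F)(F)F)cc3)CC2)o1`, is not yet measured. It differs from compound 1 in a single place: trifluoromethyl in place of fluoro on an aromatic carbon. The carbon-only six-membered aromatic ring and the rest of the shared core are unchanged.

Among the measured compounds shown here, no step between two measured compounds is available for this difference, so the expectation rests on compound 1 alone. With fluoro and trifluoromethyl occupying the same aromatic carbon, the step from compound 1 to compound 3 is expected to be small, a number 3.5 percentage points higher from compound 1 to compound 3 (within the scatter), most likely within the scatter in either direction. Compound 3 is therefore estimated at 66% in this assay, with a range from 46% to 86%.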

Compound 3, a percentage reported as inhibition, at one concentration (the size of the read-out at that concentration, not a potency): 51.6%
For compound 3 the middle estimate is 14.4 percentage points above the measured one; low and high end bracket the measured number.
By their numbers in this assay, from the lowest: compound 3; then compounds 1 and 2 (each within the scatter of the next).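

Trifluoromethyl in place of fluoro gives the first single-place step in this series: in this assay, the change from 4-fluorophenyl to 4-(trifluoromethyl)phenyl gives a number 10.9 percentage points lower from compound 1 to compound 3 (beyond the scatter) on an otherwise unchanged structure. This shows that the aromatic carbon para to a large group is not indifferent to what it carries, and that going from one heavy atom to four at this carbon can move the read-out by more than the usual scatter, something the two earlier compounds, which differ in more than one place, could not show. Nothing available accounts for the direction of this step, so it stands as an observation on a single pair of compounds.

The compounds shown leave open how a chlorine, a methoxy group, a nitrile or plain hydrogen on this same aromatic carbon would read in this assay, and so whether the step follows the heavy-atom count at all. They also leave open whether the same exchange of fluoro for trifluoromethyl gives a step of similar size and direction on any other member of the series.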